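The source may hold more compounds than are shown below. What is called first, only, known or untested is meant among the compounds shown, and "the series" means these compounds.

Working notes on the series, read in an in vitro ADME assay on microsomes from Gut (Homo sapiens) for metabolic stability, using NADPH; on this read-out higher numbers stand for fast clearance and lower numbers for slow clearance. Compound 1 (`CC(C)(CO)CNC(=O)c1cc2cc(C#N)ccc2n1Cc1cccc(OC(F)(F)F)c1`) gives < 6 mL.min-1.g-1, which is a limit of the assay and not a number. Compound 2 (`COc1ccc(OC(F)(F)F)cc1Cn1c(C(=O)NCC(C)(C)CO)cc2cc(C#N)ccc21`) gives < 6 mL.min-1.g-1, which is also a limit. Within the data shown here, compound 3 (`CCCOc1cccc(Cn2c(C(=O)NCC(C)(C)CO)cc3cc(C#N)ccc32)c1`) gives 13 mL.min-1.g-1, the only true number so far. Compound 1 therefore stands at the limit of < 6 mL.min-1.g-1 in this assay, at which 2 of the 3 values shown sit, and its exact place cannot be read.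

Compound 4 (`N#Cc1ccc2c(c1)cc(C(=O)NCCC(O)C(F)(F)F)n2Cc1cccc(OC(F)(F)F)c1`) keeps the core of compound 1 and changes only the chain on the amide-type nitrogen: 3,3,3-trifluoro-2-hydroxypropyl in place of 1-(hydroxymethyl)-1-methylethyl on a saturated chain carbon bound to an amide-type nitrogen. Among the measured compounds shown here, no measured step touches this chain, so the evidence is indirect. One measured change is a step that the two limits leave unreadable from compound 1 to compound 2. For the measured compounds named here, the other is an at least 2.1-fold higher number from compound 1 to compound 3 (0.33 log units; beyond the scatter), the only step with a readable size, and it sits on the group at the oxygen on the aromatic ring. Neither step gives a size for the chain exchange, so no step beyond the scatter is expected in this assay, although a modest rise like that of an at least 2.1-fold higher number from compound 1 to compound 3 (0.33 log units; beyond the scatter) remains possible. The expected step is a number no lower from compound 1 to compound 4 (the limit leaves the size open). Compound 4 is estimated at 6 mL.min-1.g-1, with an expected range from 3 mL.min-1.g-1 to 13 mL.min-1.g-1.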

Compound 4, intrinsic clearance in microsomes: 26 mL.min-1.g-1
The estimate for compound 4 lay 4.3-fold (0.64 log units) below the measured number; the whole stated range lies below it.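

In this assay, the chain on the amide-type nitrogen proves to be a place where the read-out moves: 3,3,3-trifluoro-2-hydroxypropyl in place of 1-(hydroxymethyl)-1-methylethyl gives an at least 4.3-fold higher number from compound 1 to compound 4 (0.63 log units; beyond the scatter). Among these compounds, until now, the only readable step was propyl in place of trifluoromethyl on an oxygen on an aromatic ring, an at least 2.1-fold higher number from compound 1 to compound 3 (0.33 log units; beyond the scatter), so the series now has a readable step at a second place, with the rest of compound 1 kept intact. The size of the new step is only a floor, as the value for compound 1 is a limit of the assay and not a number: the limit of < 6 mL.min-1.g-1 in this assay, at which 2 of the 4 values shown sit.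

The compounds shown do not separate the trifluoromethyl end of the new chain from the other changes in the exchange, and a chain with methyl in place of that trifluoromethyl, or one ending in an amine or a carboxylic acid, would help to place the step. From the compounds shown here alone, the step to compound 2 cannot be read, as both of its values are limits, and it stays open whether the new chain would raise the number to the same degree on compound 2 or compound 3.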